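This account rests on a few compounds, and the source may have more. Where it says the series, first, only, none or still open, it means among the compounds named here.

Within the data shown here, the three measured members share one core and differ only in the aryl group on a nitrogen on an aromatic ring. Compound 1 `CCc1ccccc1Nc1ncc2cc(Oc3ccnc(C(=O)NC)c3)ccc2n1` carries a 2-ethylphenyl there. In an ADME assay on Caco-2 cells (Homo sapiens) for permeability, in the apical to basolateral direction (on this read-out higher numbers stand for higher permeability and lower numbers for lower permeability), compound 1 gives < 1 10^-6 cm/s, which is a limit of the assay rather than a number. Compound 2 `CNC(=O)c1cc(Oc2ccc3nc(Nc4cccc(Cl)c4)ncc3c2)ccn1` carries a 3-chlorophenyl instead. In this assay compound 2 gives < 1 10^-6 cm/s, again a limit. Compound 3 `CNC(=O)c1cc(Oc2ccc3nc(Nc4cccc(C(C)C)c4)ncc3c2)ccn1` carries a 3-isopropylphenyl, and in this assay compound 3 gives < 1 10^-6 cm/s, also a limit. Because (the limit of < 1 10^-6 cm/s in this assay, at which 3 of the 3 values shown sit), the steps a step that the two limits leave unreadable from compound 1 to compound 2, a step that the two limits leave unreadable from compound 1 to compound 3 and a step that the two limits leave unreadable from compound 2 to compound 3 cannot be read; compound 2 thus stands at the limit together with every other value in the set.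

Compound 4 `CNC(=O)c1cc(Oc2ccc3nc(Nc4ccc(OC)cc4)ncc3c2)ccn1` is the next member, and its change from compound 2 is 4-methoxyphenyl in place of 3-chlorophenyl on a nitrogen on an aromatic ring. Among the measured compounds shown here, no measured step gives a readable size that bears on this change, and nothing in the set points away from the limit. Compound 4 is therefore expected to sit near that limit as well, at an estimated 0.8 10^-6 cm/s with a range of 0.2 10^-6 cm/s to 3 10^-6 cm/s. The expected step is a step that the limit leaves unreadable from compound 2 to compound 4, within the scatter.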

Compound 4, apparent permeability: < 1 10^-6 cm/s
Compound 4 ended at the assay's limit (the forecaster's own chance of this, stated with the estimate: 65%); the middle value is on the limit's open side.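

None of the steps joining compound 4 to compound 1, compound 2 or compound 3 can be read in this assay, because all four compounds rest on the same limit: the limit of < 1 10^-6 cm/s in this assay, at which 4 of the 4 values shown sit.

The compounds shown leave open how far apart these four aryl groups really lie, and whether any aryl group on that nitrogen gives a value that is a number rather than a limit.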